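The compounds below may be only part of what the source reports. "The series", "measured", "known", "first", "only" and "open" are said of these compounds alone.

The measured compounds so far:

Compound 1, `COC(=O)C1=C(c2ccc(Cl)cc2)C2CCC1C2`, gives 25100 nM in an in vitro assay on COS-1 cells for inhibition of sodium-dependent dopamine transporter (Homo sapiens); a lower number here means a stronger inhibitor, a higher number a weaker inhibitor.
Compound 2, `COC(=O)C1=C(c2ccc(Cl)c(Cl)c2)C2CCC1C2`, gives 6760 nM in this assay.
Compound 3, `COC(=O)C1=C(c2ccccc2Cl)C2CCC1C2`, gives 372000 nM in this assay.

Compound 1 and compound 2 differ in a single place: chloro in place of hydrogen on an aromatic carbon. That one change produced a 3.7-fold lower number from compound 1 to compound 2 (0.57 log units; beyond the scatter), a shift large enough to stand outside the usual scatter of this kind of measurement. Compound 3 is built from the same atoms as compound 1, joined differently; the difference between the two cores is not broken down here. Its number is the highest of the three, and its gap to compound 1 and to compound 2 lies beyond the scatter in each case.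

Compound 4, `COC(=O)C1=C(c2cccc(Cl)c2Cl)C2CCC1C2`, has not yet been measured. It differs from compound 3 by chloro in place of hydrogen on an aromatic carbon, the same change, in the same surroundings, that separates compound 1 from compound 2. Among the compounds with values here, the change is known from only one measured pair, so there is no way to tell from the data alone how well it carries over to a different core. Within the data shown here, still, the one example is the best available guide. The expected step is a 3.4-fold lower number from compound 3 to compound 4 (0.53 log units; beyond the scatter), because the same change gave a 3.7-fold lower number from compound 1 to compound 2 (0.57 log units; beyond the scatter). Compound 4 is therefore estimated to give 110000 nM in this assay, most likely between 30000 nM and 350000 nM.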

Compound 4, inhibition constant: 14800 nM
Beside the measured number, compound 4's estimate is 7.4-fold (0.87 log units) above it; measured number outside the range, below it.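

In this assay, the added chloro group gave a 25-fold lower number from compound 3 to compound 4 (1.40 log units; beyond the scatter), so the change pointed the same way on the core of compound 3 as on the core of compound 1, but its size did not carry over: the same change on two cores in this assay, a 3.7-fold lower number (0.57 log units; beyond the scatter) from compound 1 to compound 2 and a 25-fold lower number (1.40 log units; beyond the scatter) from compound 3 to compound 4, 6.8-fold (0.83 log units) apart, beyond the scatter of two such steps. For a newcomer, the lesson is that in these two pairs the direction of the step held, while the size seen on one core was a poor guide to the size on the other. The two pairs do not show why the steps differ, and they cannot show whether the direction would hold on a further core or which size it would take there.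

All the substituents on the aromatic ring in the compounds shown are chloro groups, so it remains open whether a fluoro, methyl or methoxy group in the same place would give a step like either of these. The methyl ester is also the same in all four compounds, which leaves open how the numbers would respond if it were replaced by a carboxylic acid or an amide.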